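The compounds below may be only part of what the source reports. "The series", "measured", "known", "first", "only" and "open" are said of these compounds alone.

In an assay on isolated protein for inhibition of histone deacetylase 4 (Homo sapiens), read by chemiluminescence, with a stated time of 3 h (on this read-out higher numbers stand for weaker inhibition and lower numbers for stronger inhibition), three compounds have been measured so far:
compound 1 `COc1ccc(-c2cnc(NC(=O)CCCCCCNC(=O)C(O)(O)C(F)(F)F)s2)cc1` gives 2500000 nM;
compound 2 `COc1ccc2sc(NC(=O)CCCCCCNC(=O)C(O)(O)C(F)(F)F)nc2c1` gives 1900000 nM;
compound 3 `O=C(CCCCCCNC(=O)C(O)(O)C(F)(F)F)Nc1ccc(Br)cc1` gives 2600000 nM.

All three numbers sit close together. Compound 1 holds the second highest of the three; its nearest neighbour is compound 3, within the scatter, and compound 2 also lies within the scatter of compound 1, so no order among them can be read.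

Compound 4 `O=C(CCCCCCNC(=O)C(O)(O)C(F)(F)F)Nc1ncc(-c2ccccc2)s1` has not yet been measured in this assay. It differs from compound 1 in one place: hydrogen in place of methoxy on an aromatic carbon. Going by the values given here, no measured pair shows this change, so there is no step to lean on; given how tightly the three measured numbers cluster, no step beyond the scatter is expected in either direction. Compound 4 is therefore estimated at 2500000 nM, with a range from 1200000 nM to 5000000 nM. The expected step is no change at the digits printed from compound 1 to compound 4 (within the scatter).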

Compound 4, half-maximal inhibitory concentration: 2500000 nM
Compound 4: the middle estimate sits on the measured number at the digits printed, and the stated range covers the measured number.
By their numbers in this assay, from the lowest: compounds 2, 1, 4 and 3 (each within the scatter of the next).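

In this assay, going by these compounds alone, the change from 4-methoxyphenyl to phenyl gives no change at the digits printed from compound 1 to compound 4 (within the scatter), the first comparison here of two compounds that differ in one place. At this position, para to a large group, hydrogen in place of methoxy therefore leaves the number within the scatter. No supporting data bear on why this is so.

Going by these compounds, whether an amine or a carboxylic acid at this position would give a step beyond the scatter remains open. So does the effect of a longer chain on the shared core.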